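Cyano in Place of Bromo: Expected Cytotoxicity of Compound 3

A few compounds are considered here, and "the series" means these few. Any claim that something is new, unique, unknown or untested is made for them only; others in the source may bear on it.

Measured compounds:
compound 1 `O=C1c2sccc2N(Cc2ccccc2)S(=O)(=O)N1Cc1ccccc1`: 37500 nM
compound 2 `O=C1c2sccc2N(Cc2ccccc2Br)S(=O)(=O)N1Cc1ccccc1`: > 270000 nM

Both compounds were run in an ADME assay on MT4 cells (Homo sapiens) for cytotoxicity, read by MTT assay, with a stated time of 4 days; on this read-out lower numbers stand for higher toxicity in this test and higher numbers for lower toxicity in this test. In this assay compound 1 gives 37500 nM. For compound 2 the result is only a limit, > 270000 nM, so no number is known for it. Compound 2 thus sits at the limit of > 270000 nM in this assay, at which 1 of the 2 values shown sits, the less toxic end of the pair. Among the compounds with values here, the single measured step, an at least 7.2-fold higher number from compound 1 to compound 2 (0.85 log units; beyond the scatter), concerns bromo in place of hydrogen and is the only evidence at hand.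

Compound 3 `N#Cc1ccccc1CN1c2ccsc2C(=O)N(Cc2ccccc2)S1(=O)=O` differs from compound 2 by cyano in place of bromo on an aromatic carbon. Within the data shown here, no measured step compares cyano with bromo, so the size of this change cannot be read from the data. With compound 2 already at a limit, compound 3 is expected to remain at the low-toxicity end as well. For compound 3 the expected step is an at least 1.8-fold lower number from compound 2 to compound 3 (0.25 log units; that floor lies within the scatter). Compound 3 is therefore estimated at 150000 nM, between 40000 nM and 500000 nM.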

Compound 3, half-maximal cytotoxic concentration: > 305000 nM
Compound 3 was reported as a limit (the forecaster's own chance of this, stated with the estimate: 40%); middle value at least 2.0-fold (0.30 log units) from the limit.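

In this assay the rise in the number seen with bromo is not confined to that one group: with cyano on the same aromatic carbon, the step is an at least 8.1-fold higher number from compound 1 to compound 3 (0.91 log units; beyond the scatter). For compound 3 the result is again a limit and not a number: the limit of > 305000 nM in this assay, at which 1 of the 3 values shown sits. Compound 2 and compound 3 both stand as limits, the step between them cannot be read, and neither bromo nor cyano can be placed ahead of the other.

Going by these compounds, the true values of compound 2 and compound 3 remain open, as does whether the higher number would hold for other groups on this aromatic carbon, such as an amine or a carboxylic acid. Also open, on these data alone, is whether a longer chain in place of the 2-cyanobenzyl group would stay at this end of the assay.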